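Trimming a Ring Nitrogen Substituent in an Integrin Inhibitor

A few compounds are considered here, and "the series" means these few. Any claim that something is new, unique, unknown or untested is made for them only; others in the source may bear on it.

Compound 1 `COc1ccnc(NC[C@@H]2C[C@@H](OCC(=O)NC[C@H](NC(=O)C3(C)CCCCC3)C(=O)O)CN2C(=O)OCc2ccccc2)c1` and compound 2 `COc1ccnc(NC[C@@H]2C[C@@H](OCC(=O)NC[C@H](NS(=O)(=O)c3c(C)cc(C)cc3C)C(=O)O)CN2C(=O)OCc2ccccc2)c1` share one core and differ only in the group on an amine nitrogen. In an assay on a protein complex for inhibition of integrin alpha-5/beta-1 (Homo sapiens), read by ELISA (on this read-out lower numbers stand for stronger inhibition and higher numbers for weaker inhibition), compound 1 gives 0.8 nM, and compound 2 gives 1.1 nM; the step of a 1.4-fold higher number from compound 1 to compound 2 (0.14 log units; within the scatter) shows that replacing the carbonyl-linked group by the sulfonyl-linked group leaves the number within the scatter. Compound 3 `Cc1cc(C)c(S(=O)(=O)N[C@@H](CNC(=O)CO[C@@H]2C[C@@H](CNc3ccccn3)N(CCCc3ccccc3)C2)C(=O)O)c(C)c1` keeps the same sulfonyl group but carries a different group on its ring nitrogen, and it stands highest of the three: in this assay compound 3 gives 670 nM, far above both others. Compound 4 `Cc1cc(C)c(S(=O)(=O)N[C@@H](CNC(=O)CO[C@H]2CN[C@H](CNc3ccccn3)C2)C(=O)O)c(C)c1` is compound 3 with hydrogen in place of 3-phenylpropyl on an amine nitrogen in a ring. Among the compounds with values here, no measured step turns a carbon substituent on this ring nitrogen into hydrogen, so none bears directly on the change; the single measured step concerns a different nitrogen and lay within the scatter. Without a guide, a worsening of a 3.0-fold higher number from compound 3 to compound 4 (0.47 log units; beyond the scatter) is expected, with wide uncertainty. Compound 4 is therefore estimated at 2000 nM in this assay, between 300 nM and 15000 nM.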

Compound 4, half-maximal inhibitory concentration: 286 nM
Beside the measured number, compound 4's estimate is 7.0-fold (0.84 log units) above it, outside the stated range (below it).
By their numbers in this assay, from the lowest: compounds 1 and 2 (each within the scatter of the next); then compound 4; then compound 3.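

In this assay, replacing the 3-phenylpropyl group on the amine nitrogen in the ring with hydrogen gives a 2.3-fold lower number from compound 3 to compound 4 (0.37 log units; beyond the scatter) and so a modest gain in inhibition rather than a loss. Within the data shown here, this is the first measured change at this ring nitrogen, and it shows that, on the core of compound 3, the whole chain with its aromatic ring can go without weakening inhibition. Nothing available here accounts for the shift.

Going by these compounds, it stays open whether a small group on this nitrogen, such as methyl, or a shorter arm, such as benzyl, would give a number nearer that of compound 4 or that of compound 3. On these data alone, whether hydrogen would give a similar step with other groups elsewhere on the core also stays open.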